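From 4-chlorophenyl to 3-methoxyphenyl on a shared core

The source may report more compounds than this note shows. Statements on the series, on what has been measured and on what is new or still open speak of the compounds shown alone.

Measured in a functional assay on HCT-116 cells (Homo sapiens) for antiproliferative activity, read by MTT assay; on this read-out higher numbers stand for weaker inhibition and lower numbers for stronger inhibition:
- compound 1 `Cn1c(=O)c(=O)n(C2CCCC2)c2nc(N/N=C/c3ccccc3)ncc21`: > 100000 nM, a limit of the assay
- compound 2 `Cn1c(=O)c(=O)n(C2CCCC2)c2nc(N/N=C/c3ccc(Cl)cc3)ncc21`: 9810 nM
- compound 3 `Cn1c(=O)c(=O)n(C2CCCC2)c2nc(N/N=C/c3ccc(O)c(F)c3)ncc21`: 59300 nM

Compound 2 has the lower of the two actual numbers, ahead of compound 3. The value of compound 1 is only a limit, (the limit of > 100000 nM in this assay, at which 1 of the 3 values shown sits).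

Compound 4 `COc1cccc(/C=N/Nc2ncc3c(n2)n(C2CCCC2)c(=O)c(=O)n3C)c1` has not yet been measured. It carries 3-methoxyphenyl in place of 4-chlorophenyl on a carbon with a double bond to nitrogen.

Among the compounds with values here, two measured steps bear on this change. Chloro in place of hydrogen gave an at least 10-fold lower number from compound 1 to compound 2 (1.00 log units; beyond the scatter). Replacing 4-chlorophenyl with 3-fluoro-4-hydroxyphenyl gave a 6.0-fold higher number from compound 2 to compound 3 (0.78 log units; beyond the scatter). In both cases, the compound without 4-chlorophenyl has the higher number, so a modest rise is expected in this assay on losing that group.

The expected step is a 3.6-fold higher number from compound 2 to compound 4 (0.55 log units; beyond the scatter). For compound 4 the estimated value is 35000 nM, within an expected range of 12000 nM to 100000 nM.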

Compound 4, half-maximal inhibitory concentration: 45800 nM
Estimate against measurement, compound 4: 1.3-fold (0.12 log units) below; measured number inside the range.
By their numbers in this assay, from the lowest: compound 2; then compounds 4 and 3 (each within the scatter of the next). At a limit, above all of these: compound 1.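

In this assay, 3-methoxyphenyl proves a second replacement for 4-chlorophenyl that does not hold the number of compound 2, with a 4.7-fold higher number from compound 2 to compound 4 (0.67 log units; beyond the scatter), and the two replacements stand level, with a 1.3-fold lower number from compound 3 to compound 4 (0.11 log units; within the scatter). Methoxy in place of hydrogen also gives an at least 2.1-fold lower number from compound 1 to compound 4 (0.33 log units; beyond the scatter), so chloro is not the only substituent on this ring with a step beyond the scatter. That step is only a floor, as the value of compound 1 is a limit: the limit of > 100000 nM in this assay, at which 1 of the 4 values shown sits.

The change from compound 2 to compound 4 alters both the group and its place on the ring, and the compounds shown do not separate the two. Also open, from the compounds shown here alone, is how bromo, an amine or a carboxylic acid on this ring would read in this assay.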